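Trimethylsilyl in place of hydroxymethyl on the alkyne

A few compounds are considered here, and "the series" means these few. Any claim that something is new, unique, unknown or untested is made for them only; others in the source may bear on it.

Compound 1 `CC(=O)Nc1nc(-c2cccc(NS(=O)(=O)c3ccc(C#CCO)cc3)c2)cs1` and compound 3 `CC(=O)Nc1nc(-c2cccc(NS(=O)(=O)c3cccc(C#CCO)c3)c2)cs1` are built from the same atoms joined differently; the difference between the two cores is not broken down here. In a functional assay on A-375 cells (Homo sapiens) for antiproliferative activity, read by trypan blue exclusion, with a stated time of 48 h, tested at 10 uM (a lower number here means a stronger effect, a higher number a weaker effect of the compound at the concentration tested), compound 1 gives 48.8%, and compound 3 gives 45.3%, which sits within the scatter of compound 1. Compound 2 `CC(=O)Nc1nc(-c2cccc(NS(=O)(=O)c3ccc(C#C[Si](C)(C)C)cc3)c2)cs1` carries the change (a group of 4 heavy atoms (3 carbon, 1 silicon; no ring) in place of a group of 2 heavy atoms (1 carbon, 1 oxygen; no ring), on a triple-bonded carbon). In this assay compound 2 reports < 1%, which is a limit of the assay and not a number; this is the limit of < 1% in this assay, at which 1 of the 3 values shown sits. The step is a number at least 47.8 percentage points lower from compound 1 to compound 2 (beyond the scatter). Compound 4 `CC(=O)Nc1nc(-c2cccc(NS(=O)(=O)c3cccc(C#C[Si](C)(C)C)c3)c2)cs1` is the unmeasured partner of compound 3 and carries the same change (a group of 4 heavy atoms (3 carbon, 1 silicon; no ring) in place of a group of 2 heavy atoms (1 carbon, 1 oxygen; no ring), on a triple-bonded carbon), at a place described in identical words. For compound 4 the expected step is a number 44.3 percentage points lower from compound 3 to compound 4 (beyond the scatter), because a number at least 47.8 percentage points lower from compound 1 to compound 2 (beyond the scatter) followed the same change. Compound 4 is therefore estimated at 1%, most likely again only a limit.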

Compound 4, a percentage reported as activity, at one concentration (the size of the read-out at that concentration, not a potency): 5.8%
For compound 4 the middle estimate is 4.8 percentage points below the measured one, within the range that was stated.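

In this assay, replacing hydroxymethyl with trimethylsilyl on the triple-bonded carbon carries over to the second core, giving a number 39.5 percentage points lower from compound 3 to compound 4 (beyond the scatter). The change therefore moves both cores the same way and by a large step, but the two steps cannot be said to be equal or different: the same change on two cores in this assay, a number at least 47.8 percentage points lower (beyond the scatter) from compound 1 to compound 2 and a number 39.5 percentage points lower (beyond the scatter) from compound 3 to compound 4; the limit leaves it open whether they differ. This rests on two cores only and shows nothing about how the change would behave on any other core.

The compounds shown leave open how other groups on the triple-bonded carbon would read in this assay, such as an amine, a carboxylic acid or a longer chain. They also leave open whether the trend would hold between those groups and hydroxymethyl.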